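This account rests on a few compounds, and the source may have more. Where it says the series, first, only, none or still open, it means among the compounds named here.

Within the data shown here, in a physicochemical assay for solubility, with a stated time of 24 h, tested at 30 mg/mL (on this read-out higher numbers stand for higher solubility and lower numbers for lower solubility), compound 1 (`CC(=O)N1CC2(C1)CC(NS(=O)(=O)c1ccc(OCc3cc(C)nc4ccccc34)cc1)(C(=O)NO)C2`) gives 17000000 nM and holds the higher of the two numbers known so far. Compound 2 (`Cc1cc(COc2ccc(S(=O)(=O)NC3(CC(=O)NO)CC3)cc2)c2ccccc2n1`) gives 1600000 nM as the lower number, a gap beyond the usual scatter. Compound 3 (`CC(=O)N1CC2(C1)CC(CC(=O)NO)(NS(=O)(=O)c1ccc(OCc3cc(C)nc4ccccc34)cc1)C2`) has not yet been measured. It departs from compound 1 on a saturated ring carbon of a four-membered non-aromatic ring of carbon only, where (hydroxycarbamoyl)methyl stands in place of hydroxycarbamoyl ((hydroxycarbamoyl)methyl in place of hydroxycarbamoyl on a saturated ring carbon). Among the measured compounds shown here, no measured pair isolates such a change, so the expectation is loose. Compound 2 at 1600000 nM is the only lower reference, and it points the expectation downward rather than upward. The expected change is a modest fall, a 2.1-fold lower number from compound 1 to compound 3 (0.33 log units; beyond the scatter) as estimated, close to the edge of the scatter. For compound 3 the estimate is 8000000 nM with an expected range from 2500000 nM to 25000000 nM in this measurement.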

Compound 3, solubility: 3000000 nM
For compound 3 the middle estimate is 2.7-fold (0.43 log units) above the measured one, and the stated range covers the measured number.
By their numbers in this assay, from the lowest: compounds 2 and 3 (each within the scatter of the next); then compound 1.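

In this assay, among these compounds, (hydroxycarbamoyl)methyl in place of hydroxycarbamoyl on a saturated ring carbon of the four-membered ring gives a 5.7-fold lower number from compound 1 to compound 3 (0.75 log units; beyond the scatter), the first measured pair to isolate a change at this position. The position is therefore not silent in this read-out, since this single exchange moves the number beyond the usual scatter. The step appears even though the two groups have equal counts of hydrogen-bond donors and acceptors and neither carries a net charge, and no measurement shown accounts for it.

The compounds shown leave open whether a longer chain, such as a (hydroxycarbamoyl)ethyl group, would continue in the same direction at this ring carbon, and how a carboxylic acid or an amine would read there. They also leave open whether the same exchange would give a step of similar size on a different core.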